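The compounds below may be only part of what the source reports. "The series", "measured", "known", "first", "only" and "open" are said of these compounds alone.

Measured so far in an assay on isolated protein for binding affinity to leukotriene B4 receptor 1 (Homo sapiens), tested at 1 uM; on this read-out higher numbers stand for more inhibition at the one concentration tested (going by the name of the read-out) and lower numbers for less inhibition:

Compound 1 `CCc1cc(C(C)=O)c(O)cc1OCCCCC(C)(C)C#N`: 30%
Compound 2 `CCc1cc(C(C)=O)c(O)cc1OCCCCCC(C)(C)C#N`: 53%

For the measured compounds named here, compound 2 stands highest of the two numbers in this assay; its nearest neighbour is compound 1, and the single measured step, a number 23 percentage points higher from compound 1 to compound 2 (beyond the scatter), lies beyond the scatter and is modest in size. Going by the values given here, that step is the one piece of evidence bearing on the next compound.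

Compound 3 `CCc1cc(C(C)=O)c(O)cc1OCCCCCCC(C)(C)C#N` differs from compound 2 by 2-cyano-2-methylpropyl in place of 1-cyano-1-methylethyl on a saturated chain carbon, five bonds along the chain from an oxygen on an aromatic ring. Among the compounds with values here, the change is the same kind of lengthening of the chain between the aromatic oxygen and the nitrile-bearing carbon as the one that separates compound 1 from compound 2, carried one bond further out. On the evidence of a number 23 percentage points higher from compound 1 to compound 2 (beyond the scatter) a further rise in this assay is plausible, but with only one step shown there is no way to tell whether the gain continues or has already levelled off, so the expectation is a smaller rise, with the range wide enough to include no change.

Compound 3 is therefore expected to give about 62% in this assay, with a range from 40% to 82%. That estimate amounts to an expected step of a number 9 percentage points higher from compound 2 to compound 3 (within the scatter).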

Compound 3, a percentage reported as inhibition, at one concentration (the size of the read-out at that concentration, not a potency): 30%
Estimate against measurement, compound 3: 32 percentage points above; measured number outside the range, below it.
By their numbers in this assay, from the lowest: compounds 1 and 3 (each within the scatter of the next); then compound 2.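

In this assay the lengthening that had raised the number does not carry on one bond further out: it gives a number 23 percentage points lower from compound 2 to compound 3 (beyond the scatter) and so takes back the whole of the earlier gain. Measured against the shorter chain, the change to 3-cyano-3-methylbutyl gives no change at the digits printed from compound 1 to compound 3 (within the scatter) and so the three compounds do not follow a steady trend with chain length, compound 2 alone standing clear of the other two, which cannot be told apart in this assay. Nothing measured here accounts for this turn in the numbers.

Going by these compounds, whether a longer chain than that of compound 3 stays at this level or moves again remains open, and three compounds cannot show how sharply the number depends on chain length. On these data alone, it is also open whether the same turn would appear with a carboxylic acid or an amine in place of the nitrile, and, since each number comes from one concentration, how far these differences would hold as differences in potency.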